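The compounds below may be only part of what the source reports. "The series", "measured", "known", "first", "only" and "open" are said of these compounds alone.

Measured compounds in an assay on isolated protein for inhibition of matrix metalloproteinase-9 (Homo sapiens), read by fluorescence, with a stated time of 30 min; on this read-out higher numbers stand for weaker inhibition and lower numbers for stronger inhibition:
compound 1 `COc1ccc(S(=O)(=O)N(CCn2cc(CCCF)nn2)[C@@H](C(=O)NO)C(C)C)cc1` gives 0.07 nM;
compound 2 `COc1ccc(S(=O)(=O)N(CCn2cc(COCCOCCOCCOCCOCCF)nn2)[C@@H](C(=O)NO)C(C)C)cc1` gives 2 nM;
compound 3 `Cc1ccc(S(=O)(=O)N(CCn2cc(CCCF)nn2)[C@@H](C(=O)NO)C(C)C)cc1` gives 3 nM.

Compound 4 `Cc1ccc(S(=O)(=O)N(CCn2cc(COCCOCCOCCOCCOCCF)nn2)[C@@H](C(=O)NO)C(C)C)cc1` has not yet been measured in this assay. It differs from compound 2 by methyl in place of methoxy on an aromatic carbon. The same change has been measured once already: compound 3 differs from compound 1 by methyl in place of methoxy on an aromatic carbon, and in this assay that step was a 43-fold higher number from compound 1 to compound 3 (1.63 log units; beyond the scatter). The difference between the core of compound 1 and the core of compound 2 is not broken down here; their two values simply show compound 2 with the higher number. Since the change in compound 4 sits at the same place as in compound 3, a step of similar size is expected from compound 2 to compound 4, resting on a 43-fold higher number from compound 1 to compound 3 (1.63 log units; beyond the scatter), namely a 20-fold higher number from compound 2 to compound 4 (1.30 log units; beyond the scatter). Compound 4 is therefore expected to give about 40 nM, with a likely range from 10 nM to 150 nM.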

Compound 4, half-maximal inhibitory concentration: 0.4 nM
For compound 4 the middle estimate is 100-fold (2.00 log units) above the measured one, outside the stated range (below it).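

In this assay, methyl in place of methoxy on an aromatic carbon gives a 5.0-fold lower number from compound 2 to compound 4 (0.70 log units; beyond the scatter), the opposite direction to the step seen on the core of compound 1. The change therefore does not carry over from one core to the other in either size or direction, and a step measured on one core is a poor guide to the other: the same change on two cores in this assay, a 43-fold higher number (1.63 log units; beyond the scatter) from compound 1 to compound 3 and a 5.0-fold lower number (0.70 log units; beyond the scatter) from compound 2 to compound 4, 210-fold (2.33 log units) apart, beyond the scatter of two such steps With one pair on each core, this does not show why the steps part, nor which of them is more typical of the series.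

The compounds shown leave open how the step behaves on a chain of intermediate length, with fewer ether oxygens than compound 2 carries. They also leave open whether an ethoxy group or a chlorine in place of methoxy would follow the same core dependence.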